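Adding two chlorines to the benzyl ether of compound 3

The source may hold more compounds than are shown below. What is called first, only, known or untested is meant among the compounds shown, and "the series" means these compounds.

Compound 3 `C=CCc1ccc(O)c(-c2ccc(OCc3ccccc3)c(CC=C)c2)c1` carries a free phenol on one ring and a benzyl ether on the other. In a functional assay on CNE2Z cells (Homo sapiens) for inhibition, read by MTT assay, with a stated time of 72 h (a lower number here means a stronger inhibitor, a higher number a weaker inhibitor), compound 3 gives 30300 nM. Among the measured compounds shown here, only two numbers are known here, and the nearest is compound 1 `C=CCc1ccc(O)c(-c2ccc(OCc3c(Cl)cccc3Cl)c(CC=C)c2)c1`, which in this assay gives 16400 nM; the two sit within the scatter of each other, as the change a 1.8-fold higher number from compound 1 to compound 3 (0.27 log units; within the scatter) shows. Compound 2 `C=CCc1ccc(OCc2ccccc2)c(-c2ccc(OCc3ccccc3)c(CC=C)c2)c1` reaches only a limit in this assay, > 50000 nM, and that limit is where one of the three values shown sits (the limit of > 50000 nM in this assay, at which 1 of the 3 values shown sits). The step of an at least 1.6-fold lower number from compound 2 to compound 3 (0.21 log units; that floor lies within the scatter) therefore rests on a floor that lies within the scatter.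

Compound 4 `C=CCc1ccc(O)c(-c2ccc(OCc3ccc(Cl)cc3Cl)c(CC=C)c2)c1` differs from compound 3 by 2,4-dichlorophenyl in place of phenyl on a saturated chain carbon bound to an oxygen on an aromatic ring. For the measured compounds named here, the only measured step bearing on this is the one from compound 1 to compound 3, which exchanged a dichlorophenyl for a phenyl at this same place and stayed within the scatter. Moving back from phenyl to a dichlorophenyl, now with the chlorines at the 2- and 4-positions, is therefore expected to give at most a small change, the step of a 1.5-fold lower number from compound 3 to compound 4 (0.18 log units; within the scatter) being expected to fall inside the scatter. Compound 4 is accordingly estimated at 20000 nM in this assay, with a range from 9000 nM to 45000 nM.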

Compound 4, half-maximal inhibitory concentration: 11300 nM
The estimate for compound 4 lay 1.8-fold (0.25 log units) above the measured number; low and high end bracket the measured number.
By their numbers in this assay, from the lowest: compounds 4, 1 and 3 (each within the scatter of the next, the first and the last beyond it). At a limit, above all of these: compound 2.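

Among the compounds shown here, replacing phenyl with 2,4-dichlorophenyl on a saturated chain carbon bound to an oxygen on an aromatic ring gives the first step at this place in this assay that lies beyond the scatter (a 2.7-fold lower number from compound 3 to compound 4 (0.43 log units; beyond the scatter)). The chlorine pattern itself cannot be separated here, since 2,4-dichlorophenyl and 2,6-dichlorophenyl remain within the scatter of each other (a 1.5-fold lower number from compound 1 to compound 4 (0.16 log units; within the scatter)), and compound 1 also remains within the scatter of compound 3. The data shown give no reason for the step from phenyl to 2,4-dichlorophenyl.

From the compounds shown here alone, whether a single chlorine, a methoxy group or a carboxylic acid on this benzyl ring would give a step of similar size remains open. So does whether an amine in place of the free phenol of compound 4 would preserve its number.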